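The compounds below may be only part of what the source reports. "The series", "measured", "known", "first", "only" and "open" are said of these compounds alone.

Notes on the series. Going by the values given here, compound 1 `O=S(=O)(CCC(F)(Cl)C(F)(F)Cl)c1nc2ccccc2s1` gives 10100 nM in a functional assay on MCF7 cells (Homo sapiens) for cytotoxicity, read by MTT assay, with a stated time of 48 h (a higher number here means a weaker inhibitor, a lower number a stronger inhibitor), and that is the only plain number in hand, so compound 1 stands on its own; the other value is not a number. Compound 2 `O=S(=O)(CCC(F)=C(F)F)c1nc2ccc(OC(F)F)cc2[nH]1` reaches only a limit of the assay, > 120000 nM in this assay, and nothing more can be read from it (the limit of > 120000 nM in this assay, at which 1 of the 2 values shown sits). Among the compounds with values here, no step between measured compounds can be drawn from these two. Compound 3 `O=S(=O)(CCC(F)(Cl)C(F)(F)Cl)c1nc2ccc(Cl)cc2s1` is not yet measured; it differs from compound 1 by chloro in place of hydrogen on an aromatic carbon. Within the data shown here, with no measured step to lean on, the step from compound 1 to compound 3 is expected to stay within the usual scatter, or to be small in either direction. Compound 3 is estimated at 8000 nM in this assay, with a likely range from 3000 nM to 25000 nM. That estimate implies a 1.3-fold lower number from compound 1 to compound 3 (0.10 log units; within the scatter), expected to be no more than the scatter.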

Compound 3, half-maximal inhibitory concentration: 8400 nM
For compound 3 the middle estimate is 1.1-fold (0.02 log units) below the measured one; the range from low to high includes it.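

In this assay, going by these compounds alone, chloro in place of hydrogen on an aromatic carbon gives a 1.2-fold lower number from compound 1 to compound 3 (0.08 log units; within the scatter) and is the first step that can be read, since the earlier compounds offered no pair differing in one place. This aromatic carbon therefore accepts a chlorine without a step beyond the scatter, at least on the core of compound 1. Nothing measured in hand bears on why the two values sit so close.

From the compounds shown here alone, what a methoxy group, an amine or a carboxylic acid would do at this same aromatic carbon stays open, as does whether chloro behaves alike on the other carbons of that ring. Also open, going by these compounds, is what the chain of compound 1 contributes, which a shorter chain or a longer chain on the same core would test.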